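Amide swap on the shared core: compound 3 to compound 4

The source may report more compounds than this note shows. Statements on the series, on what has been measured and on what is new or still open speak of the compounds shown alone.

Values in a physicochemical assay for lipophilicity, at pH 7.4; on this read-out lower numbers stand for lower lipophilicity and higher numbers for higher lipophilicity:
- compound 1 `Cc1cc(C(=O)NC(C)C)nn1Cc1cc(Cl)ccc1OCc1ccccc1`: > 3.7 (a limit)
- compound 2 `Cc1cc(C(=O)Nc2c(F)cccc2F)nn1Cc1cc(Cl)ccc1OCc1ccccc1`: 3.7
- compound 3 `Cc1cc(C(=O)NCc2ccccn2)nn1Cc1cc(Cl)ccc1OCc1ccccc1`: > 3.7 (a limit)

Compound 3 gives only a limit in this assay, not a number. Its position is the limit of > 3.7 in this assay, at which 2 of the 3 values shown sit.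

Compound 4 `CC(=O)Nc1cc(C)n(Cc2cc(Cl)ccc2OCc2ccccc2)n1` carries acetamido in place of ((pyridin-2-yl)methyl)carbamoyl on an aromatic carbon.

The measured steps, a number no higher from compound 1 to compound 2 (the limit leaves the size open), a step that the two limits leave unreadable from compound 1 to compound 3 and a number no lower from compound 2 to compound 3 (the limit leaves the size open), have no readable size, so they set no size for this change. Within the data shown here, the only number to anchor on is compound 2 at 3.7.

A modest fall is expected, as a number at least 0.20 log units lower from compound 3 to compound 4 (that floor lies within the scatter). For compound 4 the estimated value is 3.5, expected to lie between 3 and 4.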

Compound 4, distribution coefficient: > 3.7
Compound 4 gave a limit, no number; the forecaster's own chance of this, stated with the estimate: 40%; middle value at least 0.20 log units from the limit.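

In this assay compound 4 gives > 3.7, which is a limit and not a number. Acetamido, with no ring, in place of ((pyridin-2-yl)methyl)carbamoyl on the same aromatic carbon still ends at a limit, so this change gives no number at this position: the limit of > 3.7 in this assay, at which 3 of the 4 values shown sit. Against compound 2, the only compound with a number, the result is a number no lower from compound 2 to compound 4 (the limit leaves the size open); the other new steps cannot be read.

From the compounds shown here alone, how far compound 1, compound 3 and compound 4 lie from one another stays open. Going by these compounds, whether a primary amine or a carboxylic acid at this position would give a number in this assay also stays open.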